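The source may report more compounds than this note shows. Statements on the series, on what has been measured and on what is new or still open speak of the compounds shown alone.

Compound 1 `O=CN(C1CCCC1)C1CC1`: 4600 nM
Compound 2 `CC(C)CNC=O`: 54000 nM
Compound 3 `O=CN(C1CCC1)C1CCC1`: 19000 nM

All three were tested in an assay on isolated protein for inhibition of alcohol dehydrogenase 1C (Homo sapiens); a higher number here means a weaker inhibitor, a lower number a stronger inhibitor. Compound 1 gives the lowest number of the three, and its gaps to compound 3 and to compound 2 both lie beyond the usual scatter of repeated measurements, so on these numbers compound 1 is the strongest inhibitor shown. Compound 4 `O=CN(C1CCCC1)C1CCC1` has not yet been measured. It differs from compound 1 in one place: cyclobutyl in place of cyclopropyl on an amide-type nitrogen. Among the compounds with values here, no measured pair differs by exactly this change, so the size of the step is uncertain. Compound 3 carries cyclobutyl on both sides of the amide-type nitrogen and gives 19000 nM in this assay. On that basis the expected step is a 1.6-fold higher number from compound 1 to compound 4 (0.21 log units; within the scatter), a modest move toward a weaker inhibitor that may not clear the scatter. Compound 4 is therefore estimated at 7500 nM, with a likely range from 2500 nM to 22000 nM.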

Compound 4, inhibition constant: 47000 nM
The estimate for compound 4 lay 6.3-fold (0.80 log units) below the measured number, and the stated range ends below it.
By their numbers in this assay, from the lowest: compound 1; then compound 3; then compounds 4 and 2 (each within the scatter of the next).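

On the amide-type nitrogen, this position proves sensitive to ring size: cyclobutyl in place of cyclopropyl gives a 10-fold higher number from compound 1 to compound 4 (1.01 log units; beyond the scatter) in this assay and so a clearly weaker inhibitor. With the other neighbours of that nitrogen unchanged, moving from a three-membered to a four-membered ring is enough to produce a large loss. Nothing available explains why this small change has so large an effect.

From the compounds shown here alone, it remains open how a methyl group or an open chain such as isopropyl would behave on this nitrogen. A hydroxyl or an amine on the cyclopropyl ring is also untested in the compounds shown here.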